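Swapping 3-chlorophenyl for 4-methylphenyl on a shared core

The source may hold more compounds than are shown below. What is called first, only, known or untested is meant among the compounds shown, and "the series" means these compounds.

Among the compounds with values here, in an ADME assay on RAW264.7 cells (Mus musculus) for cytotoxicity, read by MTT assay, with a stated time of 24 h (a lower number here means that less compound is tolerated, a higher number that more compound is tolerated), compound 1 `O=C1CSC(N2N=C(c3ccc(Cl)c(Cl)c3)CC2c2ccccc2Cl)=N1` gives 143000 nM and compound 2 `O=C1CSC(N2N=C(c3ccc(Cl)c(Cl)c3)CC2c2cccc(Cl)c2)=N1` gives 165000 nM, so compound 2 stands level with the only other compound measured. Within the data shown here, the one measured step, a 1.2-fold higher number from compound 1 to compound 2 (0.06 log units; within the scatter), exchanges 2-chlorophenyl for 3-chlorophenyl on a saturated ring carbon and stays within the scatter. Compound 3 `Cc1ccc(C2CC(c3ccc(Cl)c(Cl)c3)=NN2C2=NC(=O)CS2)cc1` differs from compound 2 by a single exchange, (4-methylphenyl in place of 3-chlorophenyl on a saturated ring carbon), which puts 4-methylphenyl in place of 3-chlorophenyl at that same carbon. Among the measured compounds shown here, no measured compound carries 4-methylphenyl, so the evidence is thin and the range must stay wide. For the measured compounds named here, with only that small step as a guide, no change beyond the scatter is expected in this assay for this exchange. The estimated step, a 1.1-fold lower number from compound 2 to compound 3 (0.04 log units; within the scatter), reflects that expectation. Compound 3 is expected at 150000 nM, with 75000 nM to 300000 nM as its estimated range.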

Compound 3, half-maximal cytotoxic concentration: 279000 nM
For compound 3 the middle estimate is 1.9-fold (0.27 log units) below the measured one; the range from low to high includes it.
By their numbers in this assay, from the lowest: compounds 1, 2 and 3 (each within the scatter of the next).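

In this assay, the new steps, a 1.7-fold higher number from compound 2 to compound 3 (0.23 log units; within the scatter) and a 2.0-fold higher number from compound 1 to compound 3 (0.29 log units; within the scatter), both stay within the scatter, so all three compounds lie within the scatter of one another. The saturated ring carbon therefore holds a phenyl group bearing methyl as well as one bearing chlorine, and 4-methylphenyl gives no difference beyond the scatter from either chlorophenyl group. Nothing available explains why these numbers lie so close together.

All three groups at this carbon are substituted phenyl rings, so the compounds shown leave open whether a group of another kind, such as an amine, a carboxylic acid or a longer chain, would stay within the scatter. They also leave open what an exchange of the 3,4-dichlorophenyl group, which all three compounds share, would do in this assay.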